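The compounds below may be only part of what the source reports. "The series", "measured", "known", "first", "only" and "open" are said of these compounds alone.

Measured so far:
compound 1 `CCn1c([C@@H](C)NS(=O)(=O)c2ccc(Cl)cc2)nc2ccc(CO)cc21` gives 84 mL.min-1.g-1
compound 2 `CCn1c([C@@H](C)NS(=O)(=O)c2cccc(C#N)c2)nc2ccc(C(F)(F)F)cc21` gives > 100 mL.min-1.g-1

In an ADME assay (liver) for metabolic stability, with Liver microsome (Homo sapiens) as the target, read by LC-MS, using microsomes and NADPH, with a stated time of 5 min, at 37 degrees C (on this read-out lower numbers stand for slow clearance and higher numbers for fast clearance), compound 1 gives 84 mL.min-1.g-1. Compound 2 returns only a limit of the assay, > 100 mL.min-1.g-1, and therefore stands at the limit of > 100 mL.min-1.g-1 in this assay, at which 1 of the 2 values shown sits. Compound 3 `CCn1c([C@@H](C)NS(=O)(=O)c2cnc(NC(C)=O)s2)nc2ccc(C(F)(F)F)cc21` differs from compound 2 in one place: 2-acetamido-1,3-thiazol-5-yl in place of 3-cyanophenyl on a sulfonyl sulfur. Among the measured compounds shown here, no step between measured compounds is available to size such a change, so the expectation rests on compound 2 alone. Compound 3 is expected to shift only modestly, an at least 1.4-fold lower number from compound 2 to compound 3 (0.15 log units; that floor lies within the scatter), toward slower clearance but not clearly beyond the scatter. Compound 3 is accordingly estimated at 70 mL.min-1.g-1, within a range from 30 mL.min-1.g-1 to 150 mL.min-1.g-1.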

Compound 3, intrinsic clearance in microsomes: 15 mL.min-1.g-1
Compound 3: the middle estimate sits 4.7-fold (0.67 log units) above what was measured, and the stated range ends above it.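

Among the compounds shown here, with the rest of the molecule unchanged, this is the first reading of the group on the sulfonyl sulfur alone: 2-acetamido-1,3-thiazol-5-yl in place of 3-cyanophenyl gives an at least 6.6-fold lower number from compound 2 to compound 3 (0.82 log units; beyond the scatter) in this assay. The position can therefore move clearance beyond the scatter. The true size of the step stays open on one side, as compound 2 gives only a limit: the limit of > 100 mL.min-1.g-1 in this assay, at which 1 of the 3 values shown sits.

The compounds shown leave open whether the 1,3-thiazole ring or its acetamido group carries the step. An amine in place of the acetamido group on the same ring would begin to separate the two.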